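Replacing the nitro group of compound 3 with fluoro

The source may hold more compounds than are shown below. What is called first, only, known or untested is meant among the compounds shown, and "the series" means these compounds.

Measured in a functional assay on MIA PaCa-2 cells (Homo sapiens) for cytotoxicity, read by MTT assay, with a stated time of 72 h; on this read-out lower numbers stand for stronger inhibition and higher numbers for weaker inhibition:
- compound 1 `COC1=CC(=O)c2c(c(COc3ccc([N+](=O)[O-])cc3F)c(C)n2C)C1=O`: 3560 nM
- compound 2 `COC1=CC(=O)c2c(COc3ccc([N+](=O)[O-])cc3)c(C)n(C)c2C1=O`: 355 nM
- compound 3 `COC1=CC(=O)c2c(COc3ccc([N+](=O)[O-])cc3F)c(C)n(C)c2C1=O`: 417 nM

Compound 3 at 417 nM lies close to compound 2 at 355 nM, and compound 1 at 3560 nM stands well above both. Compound 4 `COC1=CC(=O)c2c(COc3ccc(F)cc3F)c(C)n(C)c2C1=O` differs from compound 3 at one place: fluoro in place of nitro on an aromatic carbon. Going by the values given here, only one measured step bears on this, and only loosely: a 1.2-fold higher number from compound 2 to compound 3 (0.07 log units; within the scatter), with fluoro in place of hydrogen on an aromatic carbon. Among the compounds with values here, no measured step removes a nitro, so the data give no direct size for this change. In this assay a small move towards a higher number is expected, not clearly beyond the scatter. The expected step is a 1.6-fold higher number from compound 3 to compound 4 (0.19 log units; within the scatter). For compound 4 the estimated value is 650 nM, with an expected range of 220 nM to 1900 nM.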

Compound 4, half-maximal inhibitory concentration: 75 nM
Compound 4: the middle estimate sits 8.7-fold (0.94 log units) above what was measured; the measured number lies below the stated range.
By their numbers in this assay, from the lowest: compound 4; then compounds 2 and 3 (each within the scatter of the next); then compound 1.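

In this assay, the place para to the large group proves sensitive to what it carries: a 5.6-fold lower number from compound 3 to compound 4 (0.75 log units; beyond the scatter), which lies beyond the scatter, whereas the earlier fluoro in place of hydrogen, a 1.2-fold higher number from compound 2 to compound 3 (0.07 log units; within the scatter), stayed within it. The nitro group is therefore not needed for a low number in this pair, since compound 4, which lacks it, gives the lower value. On these data alone, whether an amine, a nitrile or a methoxy group at this place would give a similarly low number remains open. The data at hand offer no explanation for the size of this step.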